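Homologating the Hydroxamic Acid Chain on a Quinazoline Acrylamide

A few compounds are considered here, and "the series" means these few. Any claim that something is new, unique, unknown or untested is made for them only; others in the source may bear on it.

Measured so far:
Compound 1 `C=CC(=O)Nc1cc2c(Nc3ccc(OCc4cccc(F)c4)c(Cl)c3)ncnc2cc1OCc1cn(CCCC(=O)NO)nn1`: 12000 nM
Compound 2 `C=CC(=O)Nc1cc2c(Nc3ccc(F)c(Cl)c3)ncnc2cc1OCc1cn(CCCC(=O)NO)nn1`: 1820 nM
Compound 3 `C=CC(=O)Nc1cc2c(Nc3ccc(OCc4cccc(F)c4)c(Cl)c3)ncnc2cc1OCc1cn(CCC(=O)NO)nn1`: 21000 nM

In a functional assay on NCI-H1975 cells (Homo sapiens) for antiproliferative activity, read by MTT assay, with a stated time of 72 h (a higher number here means a weaker inhibitor, a lower number a stronger inhibitor), compound 2 gives the lowest number of the three; the step from compound 1 to compound 2 is a 6.6-fold lower number from compound 1 to compound 2 (0.82 log units; beyond the scatter), a change of fluoro in place of (3-fluorobenzyl)oxy on an aromatic carbon. Compound 3 and compound 1 differ by (hydroxycarbamoyl)methyl in place of hydroxycarbamoyl on a saturated chain carbon, two bonds along the chain from an aromatic nitrogen, and that step is a 1.8-fold lower number from compound 3 to compound 1 (0.24 log units; within the scatter).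

Compound 4 `C=CC(=O)Nc1cc2c(Nc3ccc(F)c(Cl)c3)ncnc2cc1OCc1cn(CCCCC(=O)NO)nn1` is not yet measured. It differs from compound 2 by (hydroxycarbamoyl)methyl in place of hydroxycarbamoyl on a saturated chain carbon, three bonds along the chain from an aromatic nitrogen. The difference between the cores of compound 2 and compound 3 is not broken down here. The change from compound 2 to compound 4 is the same kind of change as that from compound 3 to compound 1, but the place differs: two bonds along the chain from an aromatic nitrogen in one, three bonds in the other. Because a 1.8-fold lower number from compound 3 to compound 1 (0.24 log units; within the scatter) lay within the scatter, the step from compound 2 to compound 4 in this assay is expected to be small, about a 1.2-fold lower number from compound 2 to compound 4 (0.08 log units; within the scatter). Compound 4 is therefore estimated at 1500 nM, between 600 nM and 4000 nM.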

Compound 4, half-maximal inhibitory concentration: 2500 nM
Compound 4: the middle estimate sits 1.7-fold (0.22 log units) below what was measured; measured number inside the range.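

Setting (hydroxycarbamoyl)methyl in place of hydroxycarbamoyl on a saturated chain carbon, three bonds along the chain from an aromatic nitrogen, gives in this assay a 1.4-fold higher number from compound 2 to compound 4 (0.14 log units; within the scatter). Set beside the same change on the other core, this step cannot be told apart from the earlier one: the same change on two cores in this assay, a 1.8-fold lower number (0.24 log units; within the scatter) from compound 3 to compound 1 and a 1.4-fold higher number (0.14 log units; within the scatter) from compound 2 to compound 4, 2.4-fold (0.38 log units) apart, within the scatter of two such steps

Within the data shown here, this shows that the change made no step beyond the scatter on either core, but it rests on only two pairs, at different places on the chain, and it establishes neither a direction for the change nor its behaviour on other cores. The compounds shown leave open whether a chain longer than 4-(hydroxycarbamoyl)butyl would also leave the number within the scatter. They also leave open how a carboxylic acid in place of the hydroxycarbamoyl group would read on either core.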